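A methyl-to-chloro exchange in an antiproliferative series

A few compounds are considered here, and "the series" means these few. Any claim that something is new, unique, unknown or untested is made for them only; others in the source may bear on it.

In a functional assay on CCRF-CEM cells (Homo sapiens) for antiproliferative activity, read by trypan blue exclusion, with a stated time of 72 h (a higher number here means a weaker inhibitor, a lower number a stronger inhibitor), two compounds have been measured so far. Compound 1 `CC(Br)C(=O)Nc1cc(C(=O)NC(N)=O)ccc1Cl` gives 9800 nM, and compound 2 `Cc1ccc(C(=O)NC(N)=O)cc1NC(=O)CCl` gives 3360 nM. Compound 2 therefore holds the lower number of the pair, and its gap to compound 1 lies beyond the usual scatter of repeated measurements. Compound 3 `NC(=O)NC(=O)c1ccc(Cl)c(NC(=O)CCl)c1` has not yet been measured. It departs from compound 2 at a single place: chloro in place of methyl on an aromatic carbon. The exchange sits ortho to a ((chloromethyl)carbonyl)amino group and para to a carbamoylcarbamoyl group. Going by the values given here, no two measured compounds differ in one place alone, so the data hold no direct measure of this exchange. Compound 3 keeps the ((chloromethyl)carbonyl)amino group of compound 2, so the expectation starts from the 3360 nM of compound 2. A change beyond the scatter in this assay is not expected, and no direction is favoured. The expected step is a 1.1-fold lower number from compound 2 to compound 3 (0.05 log units; within the scatter), which stays within the scatter. For compound 3 the estimated value is 3000 nM, with an expected range of 1000 nM to 9000 nM.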

Compound 3, half-maximal inhibitory concentration: 15900 nM
Beside the measured number, compound 3's estimate is 5.3-fold (0.72 log units) below it, outside the stated range (above it).
By their numbers in this assay, from the lowest: compound 2; then compounds 1 and 3 (each within the scatter of the next).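

In this assay, going by these compounds alone, the aromatic carbon ortho to a ((chloromethyl)carbonyl)amino group and para to a carbamoylcarbamoyl group proves sensitive to what it carries: chloro in place of methyl gives a 4.7-fold higher number from compound 2 to compound 3 (0.68 log units; beyond the scatter) as the first direct reading of this exchange, a modest step but one that can be told from the noise. The other exchange now readable, chloromethyl in place of 1-bromoethyl on a carbonyl carbon with chloro held on the ring, gives a 1.6-fold higher number from compound 1 to compound 3 (0.21 log units; within the scatter) and so cannot be told from the noise, which leaves compound 2, with methyl on the ring, ahead of both chloro compounds in this pair of comparisons. Nothing in the material at hand accounts for the size or direction of the ring step.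

The compounds shown leave open how hydrogen, fluoro or methoxy on this aromatic carbon would stand against methyl and chloro, since a single exchange sets no trend. Also open, on these data alone, is whether the exchange keeps its size with 1-bromoethyl in place of chloromethyl on the carbonyl carbon.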